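Dropping the Hydroxy: Compound 1 to Compound 4

The source may report more compounds than this note shows. Statements on the series, on what has been measured and on what is new or still open speak of the compounds shown alone.

Compound 1, `O=C(CN(c1ncnc2c1ncn2C1CCCCO1)C1CC1)N[C@@H](CO)C(=O)OCc1ccccc1`, gives 46.7% in a functional assay on the whole organism (Tail, strain ICR) with Mus musculus as the target, in the tail flick test, with a stated time of 60 min, at a dose of 25 umol/kg by the oral route; on this read-out lower numbers stand for a weaker effect and higher numbers for a stronger effect at the one dose given.
Compound 2, `C[C@@H](O)[C@H](NC(=O)CN(c1nc(Cl)nc2[nH]cnc12)C1CC1)C(=O)O`, gives 30.1% in this assay.
Compound 3, `C[C@H](NC(=O)CN(c1nc(Cl)nc2[nH]cnc12)C1CC1)C(=O)O`, gives 44.6% in this assay.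

Of the three measured compounds, compound 1 has the highest number in this assay; compound 3 lies within the scatter of it, while compound 2 sits beyond the scatter below it.

The unmeasured compound 4, `C[C@H](NC(=O)CN(c1ncnc2c1ncn2C1CCCCO1)C1CC1)C(=O)OCc1ccccc1`, differs from compound 1 in one place: hydrogen in place of hydroxy on a saturated chain carbon, two bonds along the chain from an amide-type nitrogen and a carbonyl carbon. Read one bond further out, the change is hydroxymethyl to methyl, which is the serine-to-alanine type of change on the amide-bound chain carbon.

Going by the values given here, one measured step bears on this. From compound 2 to compound 3 the change is methyl in place of 1-hydroxyethyl on the corresponding chain carbon, on a different core and with a free acid in place of the benzyl ester, and it gave a number 14.5 percentage points higher from compound 2 to compound 3 (beyond the scatter). Removing a hydroxy from that side chain therefore raised the read-out in this assay by a modest amount in the one case available. Compound 4 is consequently expected to move upward from compound 1 by a step of a number 9.3 percentage points higher from compound 1 to compound 4 (within the scatter), though the core and ester differ from the pair that supplies the precedent, so the expectation is loose. Compound 4 is estimated to give 56% in this assay, with a range from 40% to 72%.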

Compound 4, a percentage reported as activity, at one dose (the size of the read-out at that dose, not a potency): 53%
Compound 4: the middle estimate sits 3 percentage points above what was measured; the range from low to high includes it.
By their numbers in this assay, from the lowest: compound 2; then compounds 3, 1 and 4 (each within the scatter of the next).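

Compound 1 and compound 4 share the core and the benzyl ester, so this pair isolates hydrogen in place of hydroxy on a saturated chain carbon, two bonds along the chain from an amide-type nitrogen and a carbonyl carbon, and in this assay it gives a number 6.3 percentage points higher from compound 1 to compound 4 (within the scatter). The read-out therefore holds within the scatter when the hydroxymethyl becomes methyl, so on this core and ester the hydroxy is not required to retain the effect at the one dose given, whereas the earlier step, a number 14.5 percentage points higher from compound 2 to compound 3 (beyond the scatter), came from a different side chain, core and acid end and could not show this. Nothing in the data explains why the read-out holds at this position.

On these data alone, it remains open how an amine, a methoxy group or a longer chain such as propyl would fare at this chain carbon in place of the hydroxymethyl or methyl. As far as these compounds go, how the benzyl ester compares with a carboxylic acid on one unchanged core, with the chain held constant, also stays open.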